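From 4-bromophenyl to phenyl in an antiproliferative series

The compounds below may be only part of what the source reports. "The series", "measured", "known", "first", "only" and "open" are said of these compounds alone.

In a functional assay on MCF7 cells (Homo sapiens) for antiproliferative activity, read by MTT assay, with a stated time of 24 h (on this read-out higher numbers stand for weaker inhibition of growth and lower numbers for stronger inhibition of growth), compound 2 (`NC(=S)N1N=C(c2ccc(Br)cc2)CC1c1ccc2ccccc2c1`) gives 440 nM. Compound 3 (`Clc1ccc(C2=NN(c3ccccc3)C(c3ccc4ccccc4c3)C2)cc1`) gives 530 nM, which lies within the scatter of compound 2. Compound 1 (`NC(=S)N1N=C(c2ccc(Cl)c(Cl)c2)CC1c1ccc(O)cc1`) gives 27600 nM, a far higher number and well beyond the scatter of compound 2, so compound 2 sits at the low end of these values alongside compound 3.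

Compound 4 (`NC(=S)N1N=C(c2ccccc2)CC1c1ccc2ccccc2c1`) departs from compound 2 in one place, with hydrogen in place of bromo on an aromatic carbon, para to a large group: hydrogen in place of bromo on an aromatic carbon. Within the data shown here, no measured pair isolates this change, and every measured compound carries a halogen, so the data give no direct size for it. In this assay, a small step toward a higher number is expected, one that may not clear the scatter. The estimated change is a 1.8-fold higher number from compound 2 to compound 4 (0.26 log units; within the scatter). For compound 4 the expected value is 800 nM, with an estimated range of 250 nM to 2500 nM.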

Compound 4, concentration for 50% growth inhibition: 13800 nM
Beside the measured number, compound 4's estimate is 17-fold (1.24 log units) below it; the measured number lies above the stated range.
By their numbers in this assay, from the lowest: compounds 2 and 3 (each within the scatter of the next); then compounds 4 and 1 (each within the scatter of the next).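

In this assay, the place on the aromatic ring para to a large group proves far from indifferent: hydrogen in place of bromo gives a 31-fold higher number from compound 2 to compound 4 (1.50 log units; beyond the scatter), a large step well beyond the scatter. Compound 4 is the first compound shown without a halogen, and this single change, with the rest of the molecule the same, gives up most of the growth inhibition seen for compound 2. Nothing measured here bears on the reason for a step of this size.

Going by these compounds, whether the step is particular to bromo remains open, as does how a chloro, a methoxy or an amine at this place would compare with bromo and hydrogen. Also open, on these data alone, is whether the same change would give a step of this size on the core of compound 3.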